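Trimming a Benzamide: From Chloro-Fluoro to Methyl

A few compounds are considered here, and "the series" means these few. Any claim that something is new, unique, unknown or untested is made for them only; others in the source may bear on it.

Three amides sharing one core have been tested in a functional assay on HEK293 cells for agonist activity at D(4) dopamine receptor (Homo sapiens), read by FLIPR; on this read-out lower numbers stand for an effect already at smaller amounts and higher numbers for an effect only at larger amounts of compound. In this assay compound 1 `Cc1cc(C(=O)NCN2CCC(c3cccc[n+]3[O-])CC2)ccc1F` gives 50 nM. Compound 2 `O=C(NCN1CCC(c2cccc[n+]2[O-])CC1)c1ccccc1` gives 532 nM. Compound 3 `O=C(NCN1CCC(c2cccc[n+]2[O-])CC1)c1ccc(F)c(Cl)c1` gives 63 nM. Of the three numbers, compound 3 stands close to compound 1, the pair showing a 1.3-fold higher number from compound 1 to compound 3 (0.10 log units; within the scatter), and far from compound 2, the pair showing an 8.4-fold lower number from compound 2 to compound 3 (0.93 log units; beyond the scatter). Compound 4 `Cc1cccc(C(=O)NCN2CCC(c3cccc[n+]3[O-])CC2)c1` has not yet been measured. It differs from compound 3 by 3-methylphenyl in place of 3-chloro-4-fluorophenyl on a carbonyl carbon. Among the measured compounds shown here, two measured steps bear on this change. Decorating the bare phenyl with chloro and fluoro gave an 8.4-fold lower number from compound 2 to compound 3 (0.93 log units; beyond the scatter), while stripping methyl and fluoro from the ring gave an 11-fold higher number from compound 1 to compound 2 (1.03 log units; beyond the scatter), and swapping methyl for chloro gave only a 1.3-fold higher number from compound 1 to compound 3 (0.10 log units; within the scatter). Compound 4 keeps a methyl but loses the fluoro, so a number somewhere between compound 1 and compound 2 seems likely. In this assay compound 4 is therefore expected to give about 130 nM, within a range of 45 nM to 400 nM. That estimate corresponds to an expected 2.1-fold higher number from compound 3 to compound 4 (0.31 log units; beyond the scatter).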

Compound 4, half-maximal effective concentration: 89 nM
Beside the measured number, compound 4's estimate is 1.5-fold (0.16 log units) above it; the range from low to high includes it.
By their numbers in this assay, from the lowest: compounds 1, 3 and 4 (each within the scatter of the next); then compound 2.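

In this assay, a single methyl on the phenyl ring is enough to separate a compound clearly from the bare phenyl, with a 6.0-fold lower number from compound 2 to compound 4 (0.78 log units; beyond the scatter); until now, only rings carrying two substituents had shown this. The 3-methylphenyl group also stands level with the 3-chloro-4-fluorophenyl group on the carbonyl carbon, with a 1.4-fold higher number from compound 3 to compound 4 (0.15 log units; within the scatter), and removing the fluoro from compound 1 stays within the scatter too, with a 1.8-fold higher number from compound 1 to compound 4 (0.25 log units; within the scatter), so among these compounds the fluoro is not needed for a number well apart from that of compound 2. No measurement shown offers a reason for these numbers.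

Going by these compounds, it remains open whether a lone chloro or a lone fluoro on the phenyl ring would serve as the lone methyl does. Also open, on these data alone, is how an ethyl, methoxy or trifluoromethyl group would fare in place of the methyl.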